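A Halogen Swap Where Every Value Is a Limit

The source may report more compounds than this note shows. Statements on the series, on what has been measured and on what is new or still open speak of the compounds shown alone.

In a functional assay on HepG2 cells (Homo sapiens) for antiproliferative activity, read by MTT assay, with a stated time of 24 h (on this read-out lower numbers stand for stronger inhibition and higher numbers for weaker inhibition), compound 2 `COc1ccc(C(=O)/C=C/c2cccc(F)c2)c2c1C=CC(C)(C)O2` gives only a limit, > 10000 nM, and no number. Compound 1 `COc1ccc(C(=O)/C=C/c2cc(OC)c(OC)c(OC)c2)c2c1C=CC(C)(C)O2` likewise returns a limit, > 10000 nM. Compound 3 `COc1ccc(C(=O)/C=C/c2cccc3ccccc23)c2c1C=CC(C)(C)O2` also sits at a limit, > 10000 nM. Compound 2 therefore stands where every value shown stands, at the limit of > 10000 nM in this assay, at which 3 of the 3 values shown sit, with nothing that sets it apart from the other two. Compound 4 `COc1ccc(C(=O)/C=C/c2cccc(Cl)c2)c2c1C=CC(C)(C)O2` has not yet been measured in this assay; it differs from compound 2 by chloro in place of fluoro on an aromatic carbon. Within the data shown here, no measured step of this kind exists here, so its size is not known from the data. Because all three values sit at the limit of > 10000 nM in this assay, at which 3 of the 3 values shown sit, compound 4 is expected to stay there too, with a step no larger than the scatter, a step that the limit leaves unreadable from compound 2 to compound 4. Compound 4 is estimated at 15000 nM, between 5000 nM and 50000 nM.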

Compound 4, half-maximal inhibitory concentration: > 10000 nM
Compound 4 was reported as a limit; the forecaster's own chance of this, stated with the estimate: 75%; the middle value is on the limit's open side.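

Compound 2 and compound 4 both stand only as limits, so the change from fluoro to chloro gives no readable step: the limit of > 10000 nM in this assay, at which 4 of the 4 values shown sit. The compounds shown leave open how far past that limit each lies, and whether the two halogens differ at all.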